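Replacing a 4-chlorobenzyl with a bromo

The compounds below may be only part of what the source reports. "The series", "measured", "known", "first", "only" and "open" are said of these compounds alone.

Of the compounds shown here, three with a shared core have been measured so far. In a functional assay on the whole organism for inhibition, with Rattus norvegicus as the target (on this read-out lower numbers stand for an effect already at smaller amounts and higher numbers for an effect only at larger amounts of compound), compound 1 `CC(C)c1ccc(OC(C)(Cc2ccc(Cl)cc2)C(=O)O)cc1` gives 1 mg/kg; 1 mg/kg; 1 mg/kg (3 entries). In this assay compound 2 `CCCCc1ccc(CC(C)(Oc2ccc(C(C)C)cc2)C(=O)O)cc1` gives 1 mg/kg. Compound 3 `CC(Cc1ccc(Cl)cc1)(Oc1ccc(Cc2ccc(Cl)cc2)cc1)C(=O)O` stands apart with > 10 mg/kg, and this is a limit of the assay, not a number.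

The next compound, compound 4 `CC(Cc1ccc(Cl)cc1)(Oc1ccc(Br)cc1)C(=O)O`, differs from compound 3 in one place, with bromo in place of 4-chlorobenzyl on an aromatic carbon. For the measured compounds named here, no pair of measured compounds shows this exact change, so the expectation has to rest on a comparison of values. Only compound 3 carries 4-chlorobenzyl at that place, whereas compound 1, with a different group there, gives 1 mg/kg; 1 mg/kg; 1 mg/kg (3 entries). In this assay a clear step towards a smaller dose is therefore expected, and the expected change is an at least 3.3-fold lower number from compound 3 to compound 4 (0.52 log units; beyond the scatter). For compound 4 the estimated value is 3 mg/kg, with an expected range from 0.8 mg/kg to 12 mg/kg.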

Compound 4, dose for half-maximal effect: < 1 mg/kg
Compound 4: no number, only a limit; the forecaster's own chance of this, stated with the estimate: 25%; at least 3.0-fold (0.47 log units) between middle value and limit.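

In this assay, bromo in place of 4-chlorobenzyl on an aromatic carbon gives an at least 10-fold lower number from compound 3 to compound 4 (1.00 log units; beyond the scatter), which lies beyond the usual scatter. For the compounds shown here, the earlier compounds showed only that compound 3 stood apart from compound 1 and compound 2; this single change shows that the group at this one place can by itself decide whether an effect appears at small doses, and that the aromatic ring of 4-chlorobenzyl is not needed there. Both ends of the step are limits of the assay rather than numbers, one for compound 3 and one for compound 4, so the true size of the step may be larger.

As far as these compounds go, how far compound 4 lies past its limit, and so how it ranks against compound 1, stays unknown. Also open, from the compounds shown here alone, is what an amine, a methoxy group or a longer chain would do at this aromatic carbon.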